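Losing the 4-aminophenyl group from compound 1

This account rests on a few compounds, and the source may have more. Where it says the series, first, only, none or still open, it means among the compounds named here.

In a functional assay on MIA PaCa-2 cells (Homo sapiens) for cytotoxicity, read by MTT assay, with a stated time of 72 h (on this read-out lower numbers stand for stronger inhibition and higher numbers for weaker inhibition), compound 1 (`Nc1ccc(-c2ccc(NC3=CC(=O)c4ncncc4C3=O)cc2)cc1`) gives 2500 nM and compound 3 (`CCc1ccc(-c2ccc(NC3=CC(=O)c4ncncc4C3=O)cc2)cc1`) gives 2000 nM in the same read-out, so neither stands apart. Compound 4 (`NC(=O)c1ccc(NC2=CC(=O)c3ncncc3C2=O)cc1`) differs from compound 1 by carbamoyl in place of 4-aminophenyl on an aromatic carbon and carries carbamoyl in place of 4-aminophenyl on an aromatic carbon. For the measured compounds named here, the one measured step that bears on this is a 1.3-fold lower number from compound 1 to compound 3 (0.10 log units; within the scatter) and it puts ethyl in place of amino while keeping the ring, so it gives no size for losing that ring. Compound 2 (`O=C1C(Nc2cccc(B(O)O)c2)=CC(=O)c2ncncc21`) also lacks that ring and reads > 10000 nM as a limit of the assay, which points towards a higher number. The expected step is a 3.2-fold higher number from compound 1 to compound 4 (0.51 log units; beyond the scatter) towards weaker inhibition. For compound 4 the estimated value is 8000 nM with 3000 nM to 25000 nM as the expected range.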

Compound 4, half-maximal inhibitory concentration: 8000 nM
The estimate for compound 4 equals the measured number at the digits printed; measured number inside the range.
By their numbers in this assay, from the lowest: compounds 3 and 1 (each within the scatter of the next); then compound 4. At a limit, above all of these: compound 2.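

Replacing the outer ring with carbamoyl moves the number beyond the scatter, whichever ring-bearing compound serves as the reference (a 3.2-fold higher number from compound 1 to compound 4 (0.51 log units; beyond the scatter); a 4.0-fold higher number from compound 3 to compound 4 (0.60 log units; beyond the scatter)). Both steps are modest, yet they show that this position responds to losing the whole 4-substituted phenyl group, whereas changing amino to ethyl on that ring did not separate the compounds. Nothing measured here explains the shift.

As far as these compounds go, it remains open whether the loss of the ring or the arrival of carbamoyl drives the change. A carboxylic acid or a methyl ester at this place could help separate the two.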